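Extending the Amide Side Chain in a Rice Growth Inhibitor

A few compounds are considered here, and "the series" means these few. Any claim that something is new, unique, unknown or untested is made for them only; others in the source may bear on it.

Measured compounds:
compound 1, `CC1=CC(=O)CC(C)(C)[C@@]1(O)/C=C/C(C)=C\C(=O)NCC(=O)O`: 5700 nM
compound 2, `CSCC[C@H](NC(=O)/C=C(C)\C=C\[C@@]1(O)C(C)=CC(=O)CC1(C)C)C(=O)O`: 16000 nM

In a functional assay on the whole organism for inhibition, with Oryza sativa as the target, with a stated time of 24 h (on this read-out lower numbers stand for stronger inhibition and higher numbers for weaker inhibition), compound 1 gives 5700 nM, the lowest of the two numbers shown, while compound 2 gives 16000 nM. Compound 3 `CC1=CC(=O)CC(C)(C)[C@@]1(O)/C=C/C(C)=C\C(=O)N[C@@H](CC(=O)O)C(=O)O` differs from compound 1 in that (carboxymethyl in place of hydrogen on a saturated chain carbon bound to an amide-type nitrogen and a carbonyl carbon). Among the compounds with values here, the only measured step at the same place is a 2.8-fold higher number from compound 1 to compound 2 (0.45 log units; beyond the scatter), a modest rise. Because that step a 2.8-fold higher number from compound 1 to compound 2 (0.45 log units; beyond the scatter) was modest, a rise of comparable size is expected for compound 3, giving a 2.1-fold higher number from compound 1 to compound 3 (0.32 log units; beyond the scatter). Compound 3 is therefore estimated at 12000 nM, with a range from 5000 nM to 30000 nM.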

Compound 3, half-maximal inhibitory concentration: 6400 nM
Compound 3: the middle estimate sits 1.9-fold (0.27 log units) above what was measured; the measured number falls inside the stated range.
By their numbers in this assay, from the lowest: compounds 1 and 3 (each within the scatter of the next); then compound 2.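

In this assay, a substituent on the saturated chain carbon bound to an amide-type nitrogen and a carbonyl carbon need not shift the number: carboxymethyl in place of hydrogen gives a 1.1-fold higher number from compound 1 to compound 3 (0.05 log units; within the scatter) and so no rise like that seen with 2-(methylsulfanyl)ethyl. The outcome at this position depends on the group that enters, with a 2.5-fold lower number from compound 2 to compound 3 (0.40 log units; beyond the scatter) between the two substituted compounds. Nothing available here bears on the reason for this difference. On these data alone, it remains open whether a methyl, an amine, or a longer chain ending in a carboxylic acid would stay level with compound 1 or move away from it.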